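Moving the Second Chlorine Around the Benzyl Ring

The source may report more compounds than this note shows. Statements on the series, on what has been measured and on what is new or still open speak of the compounds shown alone.

Of the compounds shown here, three built on one shared core have been measured in a functional assay on HT-29 cells (Homo sapiens) for inhibition, read by MTT assay, with a stated time of 48 h; on this read-out higher numbers stand for weaker inhibition and lower numbers for stronger inhibition. Compound 1 `Cc1ccc(NC(=S)NC(=O)c2ccc(OCc3cccc(Cl)c3)cc2)cc1-c1nc2ccccc2[nH]1` gives 35300 nM. Compound 2 `Cc1ccc(NC(=S)NC(=O)c2ccc(OCc3cccc(Cl)c3Cl)cc2)cc1-c1nc2ccccc2[nH]1` gives 63700 nM, the highest of the three numbers. Compound 3 `Cc1ccc(NC(=S)NC(=O)c2ccc(OCc3ccc(Cl)c(Cl)c3)cc2)cc1-c1nc2ccccc2[nH]1` gives 6270 nM. Compound 2 sits nearest to compound 1, as a 1.8-fold higher number from compound 1 to compound 2 (0.26 log units; within the scatter) shows, and furthest from compound 3, as a 10-fold lower number from compound 2 to compound 3 (1.01 log units; beyond the scatter) shows. The unmeasured compound 4 `Cc1ccc(NC(=S)NC(=O)c2ccc(OCc3ccc(Cl)cc3Cl)cc2)cc1-c1nc2ccccc2[nH]1` differs from compound 2 in one respect: 2,4-dichlorophenyl in place of 2,3-dichlorophenyl on a saturated chain carbon bound to an oxygen on an aromatic ring. Among the measured compounds shown here, two measured steps bear on this change. Adding a second chlorine gave a 1.8-fold higher number from compound 1 to compound 2 (0.26 log units; within the scatter) in one case, but a 5.6-fold lower number from compound 1 to compound 3 (0.75 log units; beyond the scatter) in the other, and the rearrangement a 10-fold lower number from compound 2 to compound 3 (1.01 log units; beyond the scatter) was large. For the measured compounds named here, no measured compound carries the 2,4-dichlorophenyl pattern itself, so the expectation is a downward step of intermediate size, a 3.2-fold lower number from compound 2 to compound 4 (0.50 log units; beyond the scatter), because compound 3 with its 3,4-dichlorophenyl gives 6270 nM. Compound 4 is therefore estimated at 20000 nM, with a range from 6000 nM to 65000 nM.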

Compound 4, half-maximal inhibitory concentration: 11600 nM
Compound 4: middle estimate off by 1.7-fold (0.24 log units), on the high side; measured number inside the range.
By their numbers in this assay, from the lowest: compounds 3 and 4 (each within the scatter of the next); then compounds 1 and 2 (each within the scatter of the next).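

Rearranging the same atoms, 2,4-dichlorophenyl in place of 2,3-dichlorophenyl gave [ a 5.5-fold lower number from compound 2 to compound 4 (0.74 log units; beyond the scatter) ], so the downward step from the 2,3-dichlorophenyl group is no longer confined to the 3,4-dichlorophenyl pattern. Among the compounds shown here, the two lower-number patterns could not be told apart, at [ a 1.9-fold higher number from compound 3 to compound 4 (0.27 log units; within the scatter) ], which leaves 2,3-dichlorophenyl as the one dichlorophenyl group of the three that stands apart. Against the single chlorine of the 3-chlorophenyl group, the change gave [ a 3.0-fold lower number from compound 1 to compound 4 (0.48 log units; beyond the scatter) ], so a second chlorine now lowers the number in two of the three dichlorophenyl compounds, with compound 2 the exception.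

No measurement at hand offers an explanation for these differences. On these data alone, whether bromo or methoxy in place of the chlorines would keep the same order remains open.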